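Halogen swap on the aryl ring of a pyridopyrimidinone amide series

The source may hold more compounds than are shown below. What is called first, only, known or untested is meant among the compounds shown, and "the series" means these compounds.

The measured compounds:

Compound 1, `CCNC(=O)c1cc(Oc2ccc(NC(=O)c3cc4cccnc4n(-c4ccc(Cl)cc4)c3=O)cc2)ccn1`, gives 330 nM in a functional assay on HT-29 cells (Homo sapiens) for antiproliferative activity, read by MTT assay, with a stated time of 72 h; a higher number here means a weaker inhibitor, a lower number a stronger inhibitor.
Compound 2, `CCNC(=O)c1cc(Oc2ccc(NC(=O)c3cc4cccnc4n(-c4ccc(Br)cc4)c3=O)cc2)ccn1`, gives 1160 nM in this assay.
Compound 3, `CCCNC(=O)c1cc(Oc2ccc(NC(=O)c3cc4cccnc4n(-c4ccc(Cl)cc4)c3=O)cc2)ccn1`, gives 390 nM in this assay.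

Compound 4, `CCCNC(=O)c1cc(Oc2ccc(NC(=O)c3cc4cccnc4n(-c4ccc(Br)cc4)c3=O)cc2)ccn1`, has not yet been measured in this assay.

Two changes run through this set. The first is the halogen swap (bromo in place of chloro on an aromatic carbon), which between the two measured compounds produced a 3.5-fold higher number from compound 1 to compound 2 (0.55 log units; beyond the scatter). The second is the chain extension (methyl in place of hydrogen on a saturated chain carbon, two bonds along the chain from an amide-type nitrogen), which produced a 1.2-fold higher number from compound 1 to compound 3 (0.07 log units; within the scatter), so compound 1 and compound 3 are not distinguishable in this assay.

Compound 4 stands to compound 3 exactly as compound 2 stands to compound 1: the difference is bromo in place of chloro on an aromatic carbon, and the place it occurs is described in the same words for both pairs, so this is the same change made on a second core. The two cores differ only by the chain extension already named, which barely moved the number.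

Because the pair of compound 1 and compound 2 showed a 3.5-fold higher number from compound 1 to compound 2 (0.55 log units; beyond the scatter), a step of similar size is expected from compound 3 to compound 4, namely a 3.3-fold higher number from compound 3 to compound 4 (0.52 log units; beyond the scatter). This rests on a single measured instance of the change, so the expectation is held loosely. For compound 4 the estimated value in this assay is 1300 nM, expected to lie between 600 nM and 3000 nM.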

Compound 4, half-maximal inhibitory concentration: 530 nM
For compound 4 the middle estimate is 2.5-fold (0.39 log units) above the measured one; the measured number lies below the stated range.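

On the second core, the swap of 4-chlorophenyl to 4-bromophenyl gave a 1.4-fold higher number from compound 3 to compound 4 (0.13 log units; within the scatter) in this assay, a step that stays within the scatter, whereas the same swap on the first core lay beyond it, yet the two steps cannot be told apart from each other: the same change on two cores in this assay, a 3.5-fold higher number (0.55 log units; beyond the scatter) from compound 1 to compound 2 and a 1.4-fold higher number (0.13 log units; within the scatter) from compound 3 to compound 4, 2.6-fold (0.41 log units) apart, within the scatter of two such steps.

The chain extension, read on the bromo pair, gave a 2.2-fold lower number from compound 2 to compound 4 (0.34 log units; beyond the scatter), which lies beyond the scatter, whereas on the chloro pair it gave a 1.2-fold higher number from compound 1 to compound 3 (0.07 log units; within the scatter), and these two steps also cannot be told apart: the same change on two cores in this assay, a 1.2-fold higher number (0.07 log units; within the scatter) from compound 1 to compound 3 and a 2.2-fold lower number (0.34 log units; beyond the scatter) from compound 2 to compound 4, 2.6-fold (0.41 log units) apart, within the scatter of two such steps.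

Going by these compounds alone, the four compounds therefore show no measurable dependence of either change on the core, but they do not show that either step carries over unchanged, since each change is seen on only two pairs.

The compounds shown leave open how the number would respond to other groups on that aromatic ring, such as fluoro, methoxy or plain hydrogen in place of the halogen, and to a longer chain or a cyclopropyl group on the amide-type nitrogen. On these data alone, it also remains open whether the same steps would appear in cell lines other than the one used here.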